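The source may report more compounds than this note shows. Statements on the series, on what has been measured and on what is new or still open speak of the compounds shown alone.

Measured so far in an ADME assay on HEK-293T cells (Homo sapiens) for cytotoxicity, read by luminescence, with a stated time of 24 h; on this read-out lower numbers stand for higher toxicity in this test and higher numbers for lower toxicity in this test:
compound 1 `COc1ccc(Cn2c(C(=O)NCc3ccccc3)cc3sccc32)cc1` gives > 100000 nM
compound 2 `COc1ccc(Cn2c(C(=O)N3CCCC3)cc3sccc32)cc1` gives > 100000 nM

Both entries are limits of the assay and not numbers. Compound 2 stands at the limit > 100000 nM, with no number to place it more exactly. Compound 1 shares that position, as the limit of > 100000 nM in this assay, at which 2 of the 2 values shown sit, shows. Within the data shown here, the only measured step bearing on the change is a step that the two limits leave unreadable from compound 1 to compound 2, so it offers no size to carry forward.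

Compound 3 `COc1ccc(Cn2c(C(=O)N3CCCCC3)cc3sccc32)cc1` differs from compound 2 in the amide group: piperidin-1-yl in place of pyrrolidin-1-yl on a carbonyl carbon. In words, piperidin-1-yl stands in place of pyrrolidin-1-yl on a carbonyl carbon. In this assay, no step beyond the scatter and no direction is expected, given the shared limit in the limit of > 100000 nM in this assay, at which 2 of the 2 values shown sit. The expected change is a number no higher from compound 2 to compound 3 (the limit leaves the size open). Compound 3 is expected near 100000 nM, with an estimated range of 40000 nM to 200000 nM.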

Compound 3, half-maximal cytotoxic concentration: > 100000 nM
Compound 3: only a limit was reported (the forecaster's own chance of this, stated with the estimate: 90%); the middle value lies on the limit itself.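

No step can be read from compound 2 to compound 3 or from compound 1 to compound 3, since all three entries are limits and not numbers: the limit of > 100000 nM in this assay, at which 3 of the 3 values shown sit.

Left open is whether any amide group on the shared core gives a readable value in this assay rather than a limit.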